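The compounds below may be only part of what the source reports. "The series", "measured", "known", "first", "only" and "open" are said of these compounds alone.

Working notes on the series. The shared core of compound 1 `c1ccc(-c2c3c(nn2C2CCC2)CCNCC3)cc1` carries a phenyl group and a cyclobutyl group; in an assay on HEK293 cells for displacement of a labelled ligand from 5-hydroxytryptamine receptor 7 (Rattus norvegicus), read by radioligand binding (a higher number here means a weaker inhibitor, a lower number a stronger inhibitor), compound 1 gives 90 nM. Compound 2 `CC(C)n1nc2c(c1-c1ccc(F)cc1)CCNCC2` carries a fluorophenyl group and an isopropyl group, and in this assay compound 2 gives 7.94 nM; 8 nM (2 entries); the entries agree closely (the several entries of compound 2 in this assay, 7.94 nM; 8 nM (2 entries)). Compound 3 `Fc1ccc(-c2c3c(nn2C2CC2)CCNCC3)cc1` carries the fluorophenyl group of compound 2 and a cyclopropyl group; in this assay compound 3 gives 100 nM, the highest of the two plain numbers in hand, with compound 1 nearest to it and within the scatter, while compound 2 sits well lower. Compound 4 `Fc1ccc(-c2c3c(nn2C2CCC2)CCNCC3)cc1` is not yet measured. Compound 4 differs from compound 3 in one place: cyclobutyl in place of cyclopropyl on an aromatic nitrogen. Among the compounds with values here, no measured pair in this assay isolates that change, so the step cannot be read from the data; the values of compound 1 and compound 3 merely show that a cyclobutyl group with phenyl and a cyclopropyl group with fluorophenyl land close together. The expected step from compound 3 to compound 4 is a 1.4-fold lower number from compound 3 to compound 4 (0.15 log units; within the scatter), small and within the scatter. Compound 4 is therefore estimated at 70 nM, with a range from 25 nM to 200 nM.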

Compound 4, inhibition constant: 150 nM
Beside the measured number, compound 4's estimate is 2.1-fold (0.33 log units) below it; the measured number falls inside the stated range.
By their numbers in this assay, from the lowest: compounds 1, 3 and 4 (each within the scatter of the next).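

In this assay the ring on the aromatic nitrogen can now be read on its own: cyclobutyl in place of cyclopropyl gives a 1.5-fold higher number from compound 3 to compound 4 (0.18 log units; within the scatter) and so stays inside the scatter. With the cyclobutyl group held fixed, fluoro in place of hydrogen on an aromatic carbon gives a 1.7-fold higher number from compound 1 to compound 4 (0.22 log units; within the scatter) and likewise stays inside the scatter, so neither single change separates these compounds. No available evidence bears on these two steps.

On these data alone, with isopropyl on that nitrogen, compound 2 gives 7.94 nM; 8 nM (2 entries) and stands well apart from compound 4 at 150 nM, but whether that gap persists with an unsubstituted phenyl group remains open. Also open, as far as these compounds go, is how an open-chain amine or a longer alkyl chain on the same nitrogen would compare.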